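Methylsulfonyl in Place of Fluoro: A Limit Expected Again

The compounds below may be only part of what the source reports. "The series", "measured", "known", "first", "only" and "open" are said of these compounds alone.

Two measured compounds share one core and were tested in a functional assay on BGC-823 cells (Homo sapiens) for cytotoxicity, read by CCK-8 assay, with a stated time of 24 h; a higher number here means a weaker inhibitor, a lower number a stronger inhibitor. Compound 1 `C/C(=C\c1cc(-c2ccccc2)cs1)C(N)=O` is the parent. In this assay compound 1 gives > 50000 nM, which is a limit of the assay rather than a number. Compound 2 `C/C(=C\c1cc(-c2ccc(F)cc2)cs1)C(N)=O` carries a fluoro in place of hydrogen on an aromatic carbon. In this assay compound 2 gives > 50000 nM, again a limit and not a number. The step that the two limits leave unreadable from compound 1 to compound 2 cannot be read in size, and compound 2 stands where every value shown stands, as recorded in the limit of > 50000 nM in this assay, at which 2 of the 2 values shown sit. Compound 3 `C/C(=C\c1cc(-c2ccc(S(C)(=O)=O)cc2)cs1)C(N)=O` differs from compound 2 by methylsulfonyl in place of fluoro on an aromatic carbon. Among the measured compounds shown here, no measured step carries a readable size, and the expected step that the limit leaves unreadable from compound 2 to compound 3 is accordingly small, with a limit the most likely outcome. Compound 3 is estimated to give about 70000 nM in this assay, within 20000 nM to 250000 nM.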

Compound 3, half-maximal inhibitory concentration: > 50000 nM
Compound 3: only a limit was reported; the forecaster's own chance of this, stated with the estimate: 80%; the middle value lies beyond the limit too.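

Among the compounds shown here, no step among compound 1, compound 2 and compound 3 can be read in size, since each result is a limit of the assay and not a number: the limit of > 50000 nM in this assay, at which 3 of the 3 values shown sit. As far as these compounds go, whether any group at this place on the shared core gives a readable value in this assay stays open.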